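Compound 3 to Compound 4: A Ring Swap at the Amide Nitrogen

This account rests on a few compounds, and the source may have more. Where it says the series, first, only, none or still open, it means among the compounds named here.

Three compounds built on a shared core have been examined in a functional assay on KB cells (Homo sapiens) for antiproliferative activity, read by MTT assay, with a stated time of 48 h; a higher number here means a weaker inhibitor, a lower number a stronger inhibitor. Compound 1 `Cn1cc(C2=C(c3nn(CCn4ccnc4)c4ncccc34)C(=O)NC2=O)c2ccccc21` reaches only the limit of this assay, giving > 100000 nM. Compound 2 `Cn1cc(C2=C(c3n[nH]c4ncccc34)C(=O)N(c3cccc4ccccc34)C2=O)c2ccccc21` likewise gives no number in this assay, only the limit of > 100000 nM. Compound 3 `Cn1cc(C2=C(c3nn(CCCN4CCCCC4)c4ncccc34)C(=O)N(c3ccccn3)C2=O)c2ccccc21` also stops at the limit, with > 100000 nM in this assay.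

Compound 3 therefore stands nowhere in particular on a scale of numbers: all that is known is that it does not act within the range the assay can resolve, and the same holds for its two companions because all three sit at the limit of > 100000 nM in this assay, at which 3 of the 3 values shown sit. For the measured compounds named here, no step between two measured compounds can be drawn from these data, so the size of any change remains unknown.

Compound 4 `Cn1cc(C2=C(c3nn(CCCN4CCCCC4)c4ncccc34)C(=O)N(c3ccc(Cl)cc3)C2=O)c2ccccc21` differs from compound 3 in one place: 4-chlorophenyl in place of pyridin-2-yl on an amide-type nitrogen in a ring. Going by the values given here, with no measured step to lean on and three limits as the only background, the step from compound 3 to compound 4 is expected to be none beyond the scatter, a number no higher from compound 3 to compound 4 (the limit leaves the size open), and most probably a further limit rather than a number. Compound 4 is accordingly estimated at 100000 nM in this assay, within a range from 30000 nM to 300000 nM.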

Compound 4, half-maximal inhibitory concentration: > 100000 nM
Compound 4 ended at the assay's limit (the forecaster's own chance of this, stated with the estimate: 80%); the middle value lies on the limit itself.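

Compound 3 and compound 4 both stop at a limit in this assay, so 4-chlorophenyl in place of pyridin-2-yl on the amide-type nitrogen gives no step that can be read: the limit of > 100000 nM in this assay, at which 4 of the 4 values shown sit.

The compounds shown leave open whether any compound on this shared core gives a number within the range of this assay and how far the two groups truly differ.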